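This account rests on a few compounds, and the source may have more. Where it says the series, first, only, none or still open, it means among the compounds named here.

The series shares one core and varies the ring placed on a saturated chain carbon bound to a sulfur. Compound 1 `N#Cc1c(N)nc(SCc2cccnc2)c(C#N)c1-c1ccc(OCC2CC2)cc1` carries pyridin-3-yl there, and in an assay on CHO cells for displacement of a labelled ligand from adenosine receptor A3 (Homo sapiens), read by scintillation counting, with a stated time of 120 min, tested at 1 uM (on this read-out higher numbers stand for more inhibition at the one concentration tested (going by the name of the read-out) and lower numbers for less inhibition), compound 1 gives 19%. For the measured compounds named here, compound 2 `N#Cc1c(N)nc(SCc2nnn[nH]2)c(C#N)c1-c1ccc(OCC2CC2)cc1` carries 1H-tetrazol-5-yl in that place, and in this assay compound 2 gives 1%, the lowest of the two numbers known; the step of a number 18 percentage points lower from compound 1 to compound 2 (beyond the scatter) separates it from compound 1, its nearest neighbour. Compound 3 `N#Cc1c(N)nc(SCc2nc3ccccc3[nH]2)c(C#N)c1-c1ccc(OCC2CC2)cc1` is not yet measured and differs from compound 2 by 1H-benzimidazol-2-yl in place of 1H-tetrazol-5-yl on a saturated chain carbon bound to a sulfur. Going by the values given here, no measured step exchanges 1H-tetrazol-5-yl for 1H-benzimidazol-2-yl. Among the compounds with values here, the only step that bears on it is the one in which 1H-tetrazol-5-yl replaced pyridin-3-yl and the number fell; the change to compound 3 removes 1H-tetrazol-5-yl again, so some recovery is plausible, although the new ring is not pyridin-3-yl and its effect is unknown. A modest upward step, a number 9 percentage points higher from compound 2 to compound 3 (within the scatter), is therefore expected, with wide uncertainty. For compound 3 the estimate in this assay is 10%, with a range from 0% to 30%.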

Compound 3, a percentage reported as inhibition, at one concentration (the size of the read-out at that concentration, not a potency): 1%
Compound 3: middle estimate off by 9 percentage points, on the high side; the range from low to high includes it.
By their numbers in this assay, from the lowest: compounds 2 and 3 (each within the scatter of the next); then compound 1.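

In this assay the exchange of 1H-tetrazol-5-yl for 1H-benzimidazol-2-yl gives no change at the digits printed from compound 2 to compound 3 (within the scatter), so adding a six-membered aromatic ring of carbon only, and going from 5 to 9 heavy atoms, does not separate these two compounds. Against pyridin-3-yl the same place shows a number 18 percentage points lower from compound 1 to compound 3 (beyond the scatter), and so two unlike rings on the saturated chain carbon bound to a sulfur now stand beyond the scatter from compound 1, where before there was only one, though both steps are modest and all three numbers are small at the one concentration tested. Nothing available accounts for this result.

The compounds shown do not tell whether the number of compound 1 belongs to pyridin-3-yl in particular, or whether pyridin-2-yl, pyridin-4-yl or a plain phenyl ring in that place would read the same. Also open, going by these compounds, is what a carboxylic acid, an amine or a longer chain ending in pyridin-3-yl would give in this place on the shared core.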